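Amide change on the most active stereoisomer

The compounds below may be only part of what the source reports. "The series", "measured", "known", "first", "only" and "open" are said of these compounds alone.

Measured in a functional assay on QGY cells (Homo sapiens) for cytotoxicity, read by MTT assay, with a stated time of 48 h; a higher number here means a weaker inhibitor, a lower number a stronger inhibitor:
compound 1 `COc1cc([C@@H]2C[C@]2(CO)C(=O)NCc2ccc(C)cc2)cc(OC)c1OC`: 25100 nM
compound 2 `COc1cc([C@H]2C[C@]2(CO)C(=O)NCc2ccc(C)cc2)cc(OC)c1OC`: 56100 nM
compound 3 `COc1cc([C@H]2C[C@@]2(CO)C(=O)NCc2ccc(C)cc2)cc(OC)c1OC`: > 100000 nM

Compound 1 has the lower of the two actual numbers in this assay, and compound 2 is nearest, with a 2.2-fold higher number from compound 1 to compound 2 (0.35 log units; beyond the scatter). Compound 3 gives > 100000 nM, which is a limit of the assay and not a number.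

The next step leads to compound 4 `COc1cc([C@@H]2C[C@]2(CO)C(=O)Nc2ccccc2)cc(OC)c1OC`, which has phenyl in place of 4-methylbenzyl on an amide-type nitrogen. The measured steps all change configuration only: a 2.2-fold higher number from compound 1 to compound 2 (0.35 log units; beyond the scatter), an at least 3.9-fold higher number from compound 1 to compound 3 (0.60 log units; beyond the scatter) and an at least 1.7-fold higher number from compound 2 to compound 3 (0.25 log units; that floor lies within the scatter), the last with a floor inside the scatter. None of them tests this substituent, so they give only a rough scale for the size of a step. Compound 1 holds the lowest number at 25100 nM, so a modest move to a higher number is expected, similar to the step to compound 2 at 56100 nM. The expected change is a 1.6-fold higher number from compound 1 to compound 4 (0.20 log units; within the scatter). For compound 4 the estimated value is 40000 nM, with an expected range of 14000 nM to 100000 nM.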

Compound 4, half-maximal inhibitory concentration: 51300 nM
Compound 4: the middle estimate sits 1.3-fold (0.11 log units) below what was measured, within the range that was stated.
By their numbers in this assay, from the lowest: compound 1; then compounds 4 and 2 (each within the scatter of the next). At a limit, above all of these: compound 3.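

In this assay, the first change outside configuration gives a 2.0-fold higher number from compound 1 to compound 4 (0.31 log units; beyond the scatter), so the group on the amide-type nitrogen does affect the read-out, though the step is only modest. With the configuration of compound 1 held, the anilino amide of compound 4 stays measurable and does not reach the assay limit. Nothing on hand explains this step, as the available observations concern only configuration and the assay limit.

The step replaces 4-methylbenzyl with phenyl as a whole, so the separate contributions of the methyl group and the benzyl carbon remain unresolved, and unsubstituted benzyl on the same nitrogen would separate them. As far as these compounds go, whether a longer chain, such as 2-phenylethyl, or a basic amine on this nitrogen would lower the number also remains open.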